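From methoxy to trifluoromethyl in compound 4

A few compounds are considered here, and "the series" means these few. Any claim that something is new, unique, unknown or untested is made for them only; others in the source may bear on it.

In a functional assay on A549 cells (Homo sapiens) for antiproliferative activity, read by MTT assay, with a stated time of 24 h (on this read-out lower numbers stand for stronger inhibition and higher numbers for weaker inhibition), three compounds have been measured so far. Compound 1 (`Cc1ccc(-c2nn(-c3ccccc3)cc2-c2nc3ccccc3[nH]2)cc1`) gives 4010 nM, and compound 2 (`FC(F)(F)c1ccc(-c2nn(-c3ccccc3)cc2-c2nc3ccccc3[nH]2)cc1`) gives 3620 nM. Compound 3 (`COc1ccc(S(=O)(=O)n2c(-c3cn(-c4ccccc4)nc3-c3ccc(F)cc3)nc3ccccc32)cc1`) gives 350 nM, the lowest number of the three and clearly apart from the other two, which makes it the strongest inhibitor measured here.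

Compound 4 (`O=S(=O)(c1ccc(C(F)(F)F)cc1)n1c(-c2cn(-c3ccccc3)nc2-c2ccc(F)cc2)nc2ccccc21`) has not yet been measured. It differs from compound 3 in one place: trifluoromethyl in place of methoxy on an aromatic carbon. Trifluoromethyl stands in place of methoxy on an aromatic carbon, para to a large group, so a 4-methoxyphenyl becomes a 4-(trifluoromethyl)phenyl.

Among the measured compounds shown here, only one measured step bears on this change, and only in part. The step of a 1.1-fold lower number from compound 1 to compound 2 (0.04 log units; within the scatter) also puts trifluoromethyl on an aromatic carbon, but there it replaces methyl rather than methoxy, and both of its compounds differ from compound 3 elsewhere too. For the measured compounds named here, no measured step replaces methoxy, so the data point in neither direction, and no shift beyond the scatter is expected in this assay. The estimated change is a 1.1-fold lower number from compound 3 to compound 4 (0.04 log units; within the scatter), a small step. For compound 4 the expected value is 320 nM, with an estimated range from 130 nM to 800 nM.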

Compound 4, half-maximal inhibitory concentration: 1280 nM
Compound 4: middle estimate off by 4.0-fold (0.60 log units), on the low side; measured number outside the range, above it.
By their numbers in this assay, from the lowest: compound 3; then compound 4; then compounds 2 and 1 (each within the scatter of the next).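

In this assay, the group on this ring clearly matters: the change from 4-methoxyphenyl to 4-(trifluoromethyl)phenyl gives a 3.7-fold higher number from compound 3 to compound 4 (0.56 log units; beyond the scatter), a modest step but one beyond the scatter, and on this read-out it means weaker inhibition. Among the compounds shown here, the only earlier step that brought in trifluoromethyl, a 1.1-fold lower number from compound 1 to compound 2 (0.04 log units; within the scatter), replaced methyl in a different setting and stayed within the scatter, so it gave no sign that a swap on an aromatic carbon could move the number at all, and it said nothing about methoxy. No measurement shown here explains why the number rises, so the step stands as an observation without a cause.

For the compounds shown here, with only two groups compared at this position, the data cannot separate a gain from methoxy from a loss caused by trifluoromethyl, and a plain hydrogen, an amine or a longer chain such as ethoxy in the same place would be needed to tell these apart. As far as these compounds go, it also remains open whether the same swap gives a similar step on any other background, since this change has been read only once, between compound 3 and compound 4.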